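The compounds below may be only part of what the source reports. "The series", "measured", "known", "first", "only" and "open" are said of these compounds alone.

Measured in an ADME assay on Raji cells (Homo sapiens) for cytotoxicity, with a stated time of 72 h; on this read-out lower numbers stand for an effect already at smaller amounts and higher numbers for an effect only at larger amounts of compound:
- compound 1 `Cc1cc(NC(=O)Nc2ccc(N(C)C)cc2)c2ccccc2n1`: > 25000 nM
- compound 2 `COC(=O)c1ccc(NC(=O)Nc2cc(C)nc3ccccc23)cc1`: 17000 nM
- compound 3 `Cc1cc(NC(=O)Nc2ccc(N)cc2)c2ccccc2n1`: > 25000 nM

Compound 3 has no exact number, only the limit > 25000 nM. Compound 1 also sits at a limit, so the data show (the limit of > 25000 nM in this assay, at which 2 of the 3 values shown sit). Only compound 2 has a true number, which makes comparisons among these compounds rough.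

The next compound, compound 4 `COc1ccc(NC(=O)Nc2cc(C)nc3ccccc23)cc1`, carries methoxy in place of amino on an aromatic carbon, para to a large group: methoxy in place of amino on an aromatic carbon.

Three measured steps change the group at this same carbon. Two can be read only as floors: an at least 1.4-fold lower number from compound 1 to compound 2 (0.16 log units; that floor lies within the scatter) and an at least 1.4-fold higher number from compound 2 to compound 3 (0.16 log units; that floor lies within the scatter). The third is a step that the two limits leave unreadable from compound 1 to compound 3. None of them shows a change beyond the scatter, though the limits could hide a larger one. Methoxy itself has not been tested in this series, so these steps offer only a weak guide.

Resting on compound 2 at 17000 nM, the only true number, a small step at most is expected in this assay, toward a lower number if any. The estimated step is an at least 1.2-fold lower number from compound 3 to compound 4 (0.09 log units; that floor lies within the scatter). For compound 4 the estimated value is 20000 nM, with an expected range from 9000 nM to 35000 nM.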

Compound 4, half-maximal effective concentration: > 25000 nM
Compound 4: only a limit was reported; the forecaster's own chance of this, stated with the estimate: 50%; middle value at least 1.2-fold (0.09 log units) from the limit.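

Methoxy now joins amino and dimethylamino at this carbon of the shared core, and in this assay compound 4 also gives only a limit, leaving methoxycarbonyl in compound 2 as the one group here with a true number. Against that number, the change reads as an at least 1.4-fold higher number from compound 2 to compound 4 (0.16 log units; that floor lies within the scatter), so even the single readable step does not show that methoxy and methoxycarbonyl differ, and the steps from compound 1 and compound 3 to compound 4 cannot be read, with limits at both ends. What the new result adds is that a further group at this position ends at the same limit, so the series now gives very little to compare: the limit of > 25000 nM in this assay, at which 3 of the 4 values shown sit.

Going by these compounds, how far beyond that limit compound 1, compound 3 and compound 4 really lie stays open, and so does whether they differ from one another at all. Also open, on these data alone, is whether a carboxylic acid or a longer ester such as ethoxycarbonyl at this same carbon would give a true number, as methoxycarbonyl does, or end at the same limit.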